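Aryl sulfonyl swap within a series at the inactive limit

The source may report more compounds than this note shows. Statements on the series, on what has been measured and on what is new or still open speak of the compounds shown alone.

Two members of the series have been run in a functional assay on CHO cells for inhibition of Orexin/Hypocretin receptor type 1 (Homo sapiens), read by FLIPR and calcium flux; on this read-out lower numbers stand for stronger inhibition and higher numbers for weaker inhibition. Compound 1 `CCN(CC)C(=O)CN(c1ccc(C)cc1)S(=O)(=O)c1ccc(OC(F)(F)F)cc1` gives > 10000 nM, which is a limit of the assay and not a number. Compound 2 `CCN(CC)C(=O)CN(c1ccc(C)cc1)S(=O)(=O)c1cccc(F)c1` gives > 10000 nM, again a limit rather than a number. Both measured values thus sit on the same boundary, as the limit of > 10000 nM in this assay, at which 2 of the 2 values shown sit, records, so no step between measured compounds can be read from them; compound 2 stands at that limit with nothing shown beneath it.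

The next compound, compound 3 `CCN(CC)C(=O)CN(c1ccc(C)cc1)S(=O)(=O)c1ccc(C#N)cc1`, differs from compound 2 by 4-cyanophenyl in place of 3-fluorophenyl on a sulfonyl sulfur. Going by the values given here, no measured step offers a guide for this change. Among the compounds with values here, with both measured values at the limit, the working expectation is that compound 3 stays within the scatter of compound 2 in this assay, with no step of useful size in either direction; a move toward a measurable number is possible but is not supported by anything measured so far. Compound 3 is expected at about 15000 nM in this assay, within 3000 nM to 60000 nM. The expected step is a step that the limit leaves unreadable from compound 2 to compound 3, nothing beyond the scatter.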

Compound 3, half-maximal inhibitory concentration: > 10000 nM
Compound 3: no number, only a limit (the forecaster's own chance of this, stated with the estimate: 70%); the middle value is on the limit's open side.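

The steps from compound 2 and from compound 1 to compound 3 cannot be read, because all three compounds share one boundary: the limit of > 10000 nM in this assay, at which 3 of the 3 values shown sit.

The compounds shown leave open how far each lies beyond that limit, and whether any sulfonyl aryl group on this shared core gives a measurable number in this assay.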